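The compounds below may be only part of what the source reports. "The series", "measured", "known", "first", "only" and "open" are said of these compounds alone.

Working notes on the amide series, read in a functional assay on HCT-116 cells (Homo sapiens) for antiproliferative activity, read by resazurin assay, with a stated time of 5 days; a lower number here means a stronger inhibitor, a higher number a weaker inhibitor. Compound 1 `Cc1ccc(C(=O)NCc2ccc3cc(C(=O)NO)sc3c2F)s1` gives 120 nM, compound 2 `O=C(NCc1ccc2cc(C(=O)NO)sc2c1F)c1ccccc1` gives 980 nM and compound 3 `COc1ccccc1C(=O)NCc1ccc2cc(C(=O)NO)sc2c1F` gives 1200 nM. Compound 3 therefore sits with compound 2 and well apart from compound 1, at the high end of the numbers shown.

Compound 4 `COc1ccc(C(=O)NCc2ccc3cc(C(=O)NO)sc3c2F)cc1` carries 4-methoxyphenyl in place of 2-methoxyphenyl on a carbonyl carbon. For the measured compounds named here, no measured step makes this exact exchange. Going by the values given here, the nearest evidence is a 1.2-fold higher number from compound 2 to compound 3 (0.09 log units; within the scatter), the one measured step that adds the methoxy group, and it stays within the scatter. The larger steps, an 8.2-fold higher number from compound 1 to compound 2 (0.91 log units; beyond the scatter) and a 10-fold higher number from compound 1 to compound 3 (1.00 log units; beyond the scatter), exchange the 5-methylthiophen-2-yl group and say nothing about where the methoxy sits. No step beyond the scatter is therefore expected in this assay, and no firm direction can be given. The expected step is a 1.2-fold lower number from compound 3 to compound 4 (0.08 log units; within the scatter). The estimate for compound 4 is 1000 nM, with an expected range of 400 nM to 2500 nM.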

Compound 4, half-maximal inhibitory concentration: 50 nM
Beside the measured number, compound 4's estimate is 20-fold (1.30 log units) above it, and the stated range ends above it.
By their numbers in this assay, from the lowest: compound 4; then compound 1; then compounds 2 and 3 (each within the scatter of the next).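

In this assay, the place of the methoxy group decides the result: with the same atoms joined differently, 4-methoxyphenyl in place of 2-methoxyphenyl gives a 24-fold lower number from compound 3 to compound 4 (1.38 log units; beyond the scatter), and adding methoxy to the phenyl group, which earlier appeared to change little, gives a 20-fold lower number from compound 2 to compound 4 (1.29 log units; beyond the scatter) when it is present as 4-methoxyphenyl. The 5-methylthiophen-2-yl group also no longer gives the lowest number, as 4-methoxyphenyl in its place gives a 2.4-fold lower number from compound 1 to compound 4 (0.38 log units; beyond the scatter). No measurement shown here accounts for the difference between the two methoxy isomers.

Going by these compounds, it remains open whether this low number is specific to methoxy or extends to other groups in the same place. An amine, a carboxylic acid or a longer ether chain in place of the methoxy of compound 4 would test this.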